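Pyrrolyl for nitrofuranyl on the saturated ring carbon

The compounds below may be only part of what the source reports. "The series", "measured", "known", "first", "only" and "open" are said of these compounds alone.

Three compounds of the series have numbers in a functional assay on the whole organism (strain Wistar Albino) for inhibition, with Rattus norvegicus as the target, read by paw edema, with a stated time of 4 h, at a dose of 20 mg/kg; a higher number here means more inhibition at the dose given (going by the name of the read-out), a lower number less inhibition. Compound 1 `COc1ccc(Cc2nnc3sc(Cc4c[nH]c5ccccc45)nn23)cc1OC` gives 28.5%. Compound 2 `COc1ccc(Cc2nnc3n2NC(c2ccco2)S3)cc1OC` gives 24.6% in this assay. Compound 3 `COc1ccc(Cc2nnc3n2NC(c2ccc([N+](=O)[O-])o2)S3)cc1OC` gives 23.7% in this assay. Compound 3 stands lowest of the three numbers, its nearest neighbour being compound 2 and its furthest compound 1, yet both gaps lie within the scatter, so no order among the three can be read from them.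

For the measured compounds named here, the only one-place step measured so far is a number 0.9 percentage points lower from compound 2 to compound 3 (within the scatter), a change within the scatter.

Compound 4 `COc1ccc(Cc2nnc3n2NC(c2ccc[nH]2)S3)cc1OC` is not yet measured in this assay. It differs from compound 3 in one place: 1H-pyrrol-2-yl in place of 5-nitrofuran-2-yl on a saturated ring carbon. Going by the values given here, the measured step bears on this only in part, since it concerns the nitro group alone, while here the whole furan ring is also exchanged for a pyrrole; the ring exchange has no measured counterpart. Among the compounds with values here, with the one relevant step within the scatter and compound 2 and compound 3 within the scatter of each other, no step beyond the scatter is expected in this assay.

Compound 4 is therefore expected near 24.5%, between 15% and 34%. The step this estimate means, a number 0.8 percentage points higher from compound 3 to compound 4 (within the scatter), is expected to stay within the scatter.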

Compound 4, a percentage reported as inhibition, in the whole organism at one dose (the size of the read-out at that dose, not a potency): 21.5%
For compound 4 the middle estimate is 3 percentage points above the measured one; the measured number falls inside the stated range.
By their numbers in this assay, from the lowest: compounds 4, 3, 2 and 1 (each within the scatter of the next).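

In this assay the aromatic ring on the saturated ring carbon now has a reading of its own, and not only the nitro group on it: 1H-pyrrol-2-yl in place of 5-nitrofuran-2-yl gives a number 2.2 percentage points lower from compound 3 to compound 4 (within the scatter) and 1H-pyrrol-2-yl in place of furan-2-yl gives a number 3.1 percentage points lower from compound 2 to compound 4 (within the scatter). Together with a number 0.9 percentage points lower from compound 2 to compound 3 (within the scatter) this places furan-2-yl, 5-nitrofuran-2-yl and 1H-pyrrol-2-yl within the scatter of one another, so on the shared core neither the exchange of the ring hetero atom, with the hydrogen-bond donor it brings, nor the loss of the nitro group separates these three compounds in this read-out. No measurement at hand bears on the origin of these small steps.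

Still open, as far as these compounds go, is whether a group of another kind on the saturated ring carbon, such as an aminomethyl group, a carboxylic acid or a longer alkyl chain, would give a step beyond the scatter. Also open, from the compounds shown here alone, is whether compounds 2, 3 and 4 stay this close at other doses or at other times, since each number here is the size of the read-out at one dose and one time.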